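The source may hold more compounds than are shown below. What is called first, only, known or untested is meant among the compounds shown, and "the series" means these compounds.

Measured so far:
- compound 1 `O=C(CN1CCN(c2ccccc2)CC1)N1CCN(c2nnc(-c3ccccc3)c(-c3ccccc3)n2)CC1`: > 963000 nM
- compound 2 `O=C(CN1CCN(c2ccccc2Cl)CC1)N1CCN(c2nnc(-c3ccccc3)c(-c3ccccc3)n2)CC1`: 350000 nM
- compound 3 `O=C(CN1CCN(c2cccc(Cl)c2)CC1)N1CCN(c2nnc(-c3ccccc3)c(-c3ccccc3)n2)CC1`: 178000 nM

Working notes on the series. In an ADME assay on NIH3T3 cells (Mus musculus) for cytotoxicity, read by MTT assay, with a stated time of 24 h (a lower number here means a stronger inhibitor, a higher number a weaker inhibitor), compound 1 reaches only a limit, (the limit of > 963000 nM in this assay, at which 1 of the 3 values shown sits), and no number. Compound 2 and compound 3 give numbers, and compound 3 sits at the lower of the two, though the step of a 2.0-fold lower number from compound 2 to compound 3 (0.29 log units; within the scatter) keeps it within the scatter of compound 2.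

The steps from the unsubstituted phenyl to the chlorinated ones are the larger ones: an at least 2.7-fold lower number from compound 1 to compound 2 (0.43 log units; beyond the scatter) and an at least 5.4-fold lower number from compound 1 to compound 3 (0.73 log units; beyond the scatter), both beyond the scatter, while moving the chloro between positions, a 2.0-fold lower number from compound 2 to compound 3 (0.29 log units; within the scatter), is not.

Compound 4 `O=C(CN1CCN(c2ccc(Cl)cc2)CC1)N1CCN(c2nnc(-c3ccccc3)c(-c3ccccc3)n2)CC1` follows compound 3 by a further move of the chloro: 4-chlorophenyl in place of 3-chlorophenyl on an amine nitrogen in a ring. Among the compounds with values here, the one measured step of the same kind, a 2.0-fold lower number from compound 2 to compound 3 (0.29 log units; within the scatter), stayed within the scatter, so no step beyond the scatter is expected in this assay, a 1.2-fold lower number from compound 3 to compound 4 (0.07 log units; within the scatter). Compound 4 is therefore estimated at 150000 nM, with a range from 55000 nM to 420000 nM.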

Compound 4, half-maximal inhibitory concentration: 113000 nM
The estimate for compound 4 lay 1.3-fold (0.12 log units) above the measured number; the measured number falls inside the stated range.
By their numbers in this assay, from the lowest: compounds 4, 3 and 2 (each within the scatter of the next, the first and the last beyond it). At a limit, above all of these: compound 1.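

The move to 4-chlorophenyl gives a 1.6-fold lower number from compound 3 to compound 4 (0.20 log units; within the scatter), so in this assay compound 3 and compound 4 cannot be told apart. The series now has its first change of chloro position that exceeds the scatter, a 3.1-fold lower number from compound 2 to compound 4 (0.49 log units; beyond the scatter), showing that the place of the chloro on this phenyl can register in this assay, although the two smaller moves do not do so singly. The step from the unsubstituted phenyl, an at least 8.5-fold lower number from compound 1 to compound 4 (0.93 log units; beyond the scatter), rests on a limit and not a number for compound 1: the limit of > 963000 nM in this assay, at which 1 of the 4 values shown sits.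

From the compounds shown here alone, it remains open whether a fluoro, a methoxy or a trifluoromethyl group on the same phenyl would follow the chloro compounds. Also open, going by these compounds, is whether a second chloro on this ring would extend the step seen here.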